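The source may report more compounds than this note shows. Statements on the series, on what has been measured and on what is new or still open speak of the compounds shown alone.

Measured compounds in an ADME assay on RAW264.7 cells (Mus musculus) for cytotoxicity, read by MTT assay, with a stated time of 24 h; a higher number here means that more compound is tolerated, a lower number that less compound is tolerated:

compound 1, `CC/C=C\C[C@H]1C(=O)C=C[C@H]1CC(=O)OCCCC`, 31 uM
compound 2, `CC/C=C\C[C@H]1C(=O)C=C[C@H]1CC(=O)OCCCCC`, 37 uM
compound 3, `CC/C=C\C[C@H]1C(=O)C=C[C@H]1CC(=O)OC(C)C`, 58 uM

The three values lie within the scatter of one another. The step methyl in place of hydrogen on a saturated chain carbon, four bonds along the chain from an oxygen next to a carbonyl group gives a 1.2-fold higher number from compound 1 to compound 2 (0.08 log units; within the scatter). The cores of compound 1 and compound 3 differ by isopropyl in place of butyl on an oxygen next to a carbonyl group.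

Compound 4, `CC/C=C\C[C@H]1C(=O)C=C[C@H]1CC(=O)OC(C)CC`, is not yet measured. It differs from compound 3 by methyl in place of hydrogen on a saturated chain carbon, two bonds along the chain from an oxygen next to a carbonyl group. Within the data shown here, this is the same kind of change as the one from compound 1 to compound 2, but not the same: there the methyl enters four bonds along the chain from the oxygen next to the carbonyl group, here two bonds along that chain.

For compound 4 a step of a 1.2-fold lower number from compound 3 to compound 4 (0.06 log units; within the scatter) is expected in this assay, resting on the small step of a 1.2-fold higher number from compound 1 to compound 2 (0.08 log units; within the scatter) and on the closeness of all three measured values. The estimate for compound 4 is 50 uM, between 25 uM and 100 uM.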

Compound 4, half-maximal toxic concentration: 53 uM
For compound 4 the middle estimate is 1.1-fold (0.03 log units) below the measured one; the measured number falls inside the stated range.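

In this assay, methyl in place of hydrogen two bonds along the chain from the oxygen gives a 1.1-fold lower number from compound 3 to compound 4 (0.04 log units; within the scatter), and the two instances of this change agree: the same change on two cores in this assay, a 1.2-fold higher number (0.08 log units; within the scatter) from compound 1 to compound 2 and a 1.1-fold lower number (0.04 log units; within the scatter) from compound 3 to compound 4, 1.3-fold (0.12 log units) apart, within the scatter of two such steps

Swapping the whole group on that oxygen also stays small, with a 1.4-fold higher number from compound 2 to compound 4 (0.16 log units; within the scatter) and a 1.7-fold higher number from compound 1 to compound 4 (0.23 log units; within the scatter). This shows that the added methyl leaves the number within the scatter on both cores, but it does not show that a step of real size would carry over, and the methyl enters at a different chain place on each core, leaving place and core unseparated.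

On these data alone, whether an amine, a carboxylic acid or a longer chain on that oxygen would move the number beyond the scatter remains open. So does the effect of any change on the shared core itself.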